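The source may hold more compounds than are shown below. What is called first, only, known or untested is meant among the compounds shown, and "the series" means these compounds.

Measured in a physicochemical assay for solubility; on this read-out lower numbers stand for lower solubility and higher numbers for higher solubility:
- Compound 1 `O=C(Nc1ccc([N+](=O)[O-])cc1Cl)c1cc(F)ccc1O`: 3.3 ug/mL
- Compound 2 `O=C(Nc1ccc([N+](=O)[O-])cc1Cl)c1cc([N+](=O)[O-])ccc1O`: > 50 ug/mL

The reading for compound 2 is a limit of the assay and not a number: > 50 ug/mL. Compound 3 `O=C(Nc1ccc([N+](=O)[O-])cc1Cl)c1cc(-c2ccc(F)cc2F)ccc1O` has 2,4-difluorophenyl in place of nitro on an aromatic carbon, para to a hydroxy group: 2,4-difluorophenyl in place of nitro on an aromatic carbon. Among the measured compounds shown here, one measured step bears on this change: an at least 15-fold higher number from compound 1 to compound 2 (1.18 log units; beyond the scatter). That step brought in the nitro at this carbon, so its removal here is expected to give a large step down in this assay, towards compound 1 at 3.3 ug/mL. The expected step is an at least 20-fold lower number from compound 2 to compound 3 (1.30 log units; beyond the scatter). For compound 3 the estimate is 2.5 ug/mL, with an expected range of 0.6 ug/mL to 10 ug/mL.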

Compound 3, solubility: < 1 ug/mL
Compound 3: no number, only a limit (the forecaster's own chance of this, stated with the estimate: 15%); middle value at least 2.5-fold (0.39 log units) from the limit.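

In this assay, this carbon, para to a hydroxy group, proves to matter in the downward direction as well: 2,4-difluorophenyl in place of nitro gives an at least 50-fold lower number from compound 2 to compound 3 (1.69 log units; beyond the scatter). Removing the nitro does not simply return the read-out to the level of the fluoro compound, since 2,4-difluorophenyl in place of fluoro gives an at least 3.3-fold lower number from compound 1 to compound 3 (0.51 log units; beyond the scatter). The reading for compound 3 is a limit of the assay and not a number: the limit of < 1 ug/mL in this assay, at which 1 of the 3 values shown sits.

Going by these compounds, how far compound 3 lies past that limit stays open, and with it the true size of both steps. Also open, on these data alone, is where an amine or a carboxylic acid on this carbon would fall.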